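Swapping a Methoxypropenyl Chain for an Acetylphenyl Ring

A few compounds are considered here, and "the series" means these few. Any claim that something is new, unique, unknown or untested is made for them only; others in the source may bear on it.

Going by the values given here, compound 3 `COC/C=C/c1ccc(CN(C(=O)C2CCCCC2)c2cccc(/C=C/C(=O)OC)c2)cc1` holds the highest number so far in an assay on isolated protein with Bile acid receptor (Homo sapiens) as the target (a higher number here means that more compound is needed for the effect, a lower number that less compound is needed), giving 233 nM. Its nearest neighbour, compound 1 `COC(=O)/C=C/c1cccc(N(Cc2ccc(-c3ccc(OC)cc3)cc2)C(=O)C2CCCCC2)c1`, gives 89 nM in this assay. Compound 2 `COC(=O)/C=C/c1cccc(N(Cc2ccc(Br)cc2)C(=O)C2CCCCC2)c1` reaches only the limit of > 1000 nM in this assay. Compound 4 `COC(=O)/C=C/c1cccc(N(Cc2ccc(-c3cccc(C(C)=O)c3)cc2)C(=O)C2CCCCC2)c1` differs from compound 3 by 3-acetylphenyl in place of 3-methoxyprop-1-en-1-yl on an aromatic carbon. Among the compounds with values here, two measured steps bear on this change. The step of a 2.6-fold higher number from compound 1 to compound 3 (0.42 log units; beyond the scatter) shows that exchanging an aromatic ring for the chain raised the number, while the step of an at least 4.2-fold lower number from compound 2 to compound 3 (0.63 log units; beyond the scatter) shows the chain still beating bromo. Restoring a substituted aromatic ring is therefore expected to lower the number modestly, a 2.1-fold lower number from compound 3 to compound 4 (0.33 log units; beyond the scatter). Compound 4 is estimated at 110 nM, expected to lie within 40 nM to 300 nM.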

Compound 4, half-maximal effective concentration: 227 nM
Beside the measured number, compound 4's estimate is 2.1-fold (0.31 log units) below it, and the stated range covers the measured number.
By their numbers in this assay, from the lowest: compound 1; then compounds 4 and 3 (each within the scatter of the next). At a limit, above all of these: compound 2.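

Putting an aromatic ring at this position did not by itself lower the number in this assay: a 1.0-fold lower number from compound 3 to compound 4 (0.01 log units; within the scatter). The kind of ring matters, as 3-acetylphenyl does not match 4-methoxyphenyl: a 2.6-fold higher number from compound 1 to compound 4 (0.41 log units; beyond the scatter). 3-Acetylphenyl still improves on bromo, although the starting value is a limit of the assay: an at least 4.4-fold lower number from compound 2 to compound 4 (0.64 log units; beyond the scatter).

As far as these compounds go, what a 3-methoxyphenyl, 4-acetylphenyl or aminophenyl ring would give here remains open, so the group and its place on the ring cannot yet be separated. Nothing shown bears on why these steps fall as they do.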